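A few compounds are considered here, and "the series" means these few. Any claim that something is new, unique, unknown or untested is made for them only; others in the source may bear on it.

Compound 1 `O=C(Nc1ccc(OC(F)(F)F)cc1)c1cc(=O)[nH]c2cc(Br)ccc12` is one of three compounds with a result in a functional assay on KYSE-70 cells for antiproliferative activity against KYSE-70 cell line (Homo sapiens), read by MTT assay, with a stated time of 72 h; on this read-out higher numbers stand for weaker inhibition and lower numbers for stronger inhibition. Compound 1 gives > 20000 nM, which is a limit of the assay rather than a number. Compound 2 `COc1cccc(NC(=O)c2cc(=O)[nH]c3cc(Br)ccc23)c1` likewise gives only a limit, > 20000 nM. Compound 3 `CC(C)(C)c1ccc(-c2ccc3c(C(=O)Nc4cccc(F)c4)cc(=O)[nH]c3c2)cc1` gives > 20000 nM, again a limit. Within the data shown here, compound 3 therefore stands nowhere apart from the others: all three values sit at the limit of > 20000 nM in this assay, at which 3 of the 3 values shown sit, and no step between any two of them can be read from these numbers. Compound 4 `C=Cc1ccc2c(C(=O)Nc3cccc(F)c3)cc(=O)[nH]c2c1` is the next compound and is not yet measured. It differs from compound 3 in one place: vinyl in place of 4-(tert-butyl)phenyl on an aromatic carbon. Nothing in the series shows a change at that position moving the read-out, and nothing shows any compound leaving the limit. The expectation is that compound 4 stays where compound 3 is, the step being estimated as a step that the limit leaves unreadable from compound 3 to compound 4, which is nothing beyond the scatter. The estimate for compound 4 is 30000 nM, with a range of 8000 nM to 100000 nM, and the most likely outcome is that the assay again reports only a limit.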

Compound 4, half-maximal inhibitory concentration: 9700 nM
Compound 4: middle estimate off by 3.1-fold (0.49 log units), on the high side; the measured number falls inside the stated range.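

In this assay, vinyl in place of 4-(tert-butyl)phenyl on an aromatic carbon gives an at least 2.0-fold lower number from compound 3 to compound 4 (0.31 log units; beyond the scatter), the first sign that the read-out can move with a change at this position. Compound 3 gives > 20000 nM, which is a limit, so the step has a lower bound but no full size. Compound 4 is the only compound shown that gives a number rather than this limit: the limit of > 20000 nM in this assay, at which 3 of the 4 values shown sit.

The change removes a ring and a tert-butyl group and adds a double bond outside aromatic rings, and the compounds shown cannot separate these parts. How an ethyl group or an unsubstituted phenyl on the same carbon would read remains open, and the other steps among these compounds cannot be read.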